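A few compounds are considered here, and "the series" means these few. Any claim that something is new, unique, unknown or untested is made for them only; others in the source may bear on it.

Of the compounds shown here, two have so far been tested in an ADME assay on BEAS-2B cells (Homo sapiens) for cytotoxicity, read by MTT assay, with a stated time of 72 h; a higher number here means a weaker inhibitor of growth, a lower number a stronger inhibitor of growth. Compound 1, with structure `CCCCC[Se]c1nc(N)c2ccccc2n1`, gives 52300 nM in this assay. Compound 2, with structure `COc1ccc(CNc2nc([SeH])nc3ccccc23)cc1`, gives 37400 nM. Of these two numbers, compound 1 has the higher one, yet the gap to compound 2 lies within the usual scatter of repeated measurements, so the two values cannot really be told apart. The next compound, compound 3, has structure `C[Se]c1nc(N)c2ccccc2n1` and awaits testing. It differs from compound 1 in a single place: hydrogen in place of butyl on a saturated chain carbon bound to a selenium atom. For the measured compounds named here, no pair of measured compounds shows what this exchange does here, so there is no measured step to lean on. A modest move toward a higher number, meaning weaker inhibition of growth, seems the most likely outcome, and the expected step is a 1.3-fold higher number from compound 1 to compound 3 (0.13 log units; within the scatter). For compound 3 the estimate in this assay is 70000 nM, with a range from 30000 nM to 160000 nM.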

Compound 3, concentration for 50% growth inhibition: 23600 nM
Compound 3: middle estimate off by 3.0-fold (0.47 log units), on the high side; measured number outside the range, below it.
By their numbers in this assay, from the lowest: compounds 3, 2 and 1 (each within the scatter of the next, the first and the last beyond it).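

Putting hydrogen in place of butyl on a saturated chain carbon bound to a selenium atom, which turns pentyl into methyl, gives a 2.2-fold lower number from compound 1 to compound 3 (0.35 log units; beyond the scatter) in this assay. This first measured step at this place shows that the number responds to the chain on selenium, and that the long pentyl chain is not required for growth inhibition in these cells: of this pair, the methyl compound is the stronger inhibitor, though only modestly. Nothing measured here explains the shift.

On these data alone, with only pentyl and methyl to compare at this place, it remains open whether the number falls steadily as the chain shortens, or whether a propyl chain would land somewhere in the middle. As far as these compounds go, how a benzyl group or a chain ending in a carboxylic acid would behave at this place also remains unknown.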